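This account rests on a few compounds, and the source may have more. Where it says the series, first, only, none or still open, it means among the compounds named here.

Measured compounds:
compound 1, `Cc1cc(C(=O)Nc2ccc(F)cn2)ccc1N(CCN1CCCC1)C(=O)Nc1ccc(Cl)cc1`, 0.458 h
compound 2, `Cc1cc(C(=O)Nc2ccc(Cl)cc2)ccc1N(CCN1CCCC1=O)C(=O)Nc1ccc(Cl)cc1`, 0.158 h

In an ADME assay on microsomes from liver (Homo sapiens) for metabolic stability (a higher number here means that the compound lasts longer, a lower number that the compound disappears faster), compound 2 stands lowest of the two numbers; its nearest neighbour is compound 1, with a value higher by a margin beyond the scatter. Compound 3, `Cc1cc(C(=O)Nc2ccc(F)cn2)ccc1N(CCN1CCCC1=O)C(=O)Nc1ccc(Cl)cc1`, has not yet been measured. It differs from compound 2 by 5-fluoropyridin-2-yl in place of 4-chlorophenyl on an amide-type nitrogen. Among the compounds with values here, no measured pair isolates this change, so the direction is uncertain. A small rise is expected, a 1.3-fold higher number from compound 2 to compound 3 (0.10 log units; within the scatter), within the scatter. Compound 3 is therefore estimated at 0.2 h, with a range from 0.08 h to 0.5 h.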

Compound 3, half-life: 0.0667 h
Compound 3: the middle estimate sits 3.0-fold (0.48 log units) above what was measured, and the stated range ends above it.
By their numbers in this assay, from the lowest: compound 3; then compound 2; then compound 1.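

In this assay, 5-fluoropyridin-2-yl in place of 4-chlorophenyl on an amide-type nitrogen gives a 2.4-fold lower number from compound 2 to compound 3 (0.37 log units; beyond the scatter), so this position affects the half-life when 2-oxopyrrolidin-1-yl is held fixed. Within the data shown here, with 5-fluoropyridin-2-yl held fixed, 2-oxopyrrolidin-1-yl in place of pyrrolidin-1-yl gives a 6.9-fold lower number from compound 1 to compound 3 (0.84 log units; beyond the scatter), which isolates the chain end for the first time. Nothing available here accounts for either step.

Going by these compounds, it remains open whether the aryl change runs the same way with pyrrolidin-1-yl on the chain. On these data alone, it is also open whether the ring nitrogen or the fluorine matters more, which 4-fluorophenyl or 5-chloropyridin-2-yl could separate.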